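A few compounds are considered here, and "the series" means these few. Any claim that something is new, unique, unknown or untested is made for them only; others in the source may bear on it.

Going by the values given here, compound 1, `Cc1cccc(N2CCC(C(=O)Nc3ccc4c(c3)NC(=O)CO4)CC2)c1`, is the only compound here for which a functional assay for antagonist activity at transient receptor potential cation channel subfamily V member 1 (Homo sapiens), read by FLIPR and calcium flux (on this read-out lower numbers stand for stronger inhibition and higher numbers for weaker inhibition), gives a number: in this assay compound 1 gives 490 nM. Compound 2, `CC(=O)N1CCc2cc(NC(=O)C3CCN(c4cccc(C(F)(F)F)c4)CC3)ccc21`, is measured in this assay only as a limit, and in this assay compound 2 gives > 9000 nM; this is a limit of the assay and not a number, so that (the limit of > 9000 nM in this assay, at which 1 of the 2 values shown sits), and nothing about the size of any step between compound 1 and compound 2 can be read from it, since the two compounds also differ in their core.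

Compound 3, `O=C1COc2ccc(NC(=O)C3CCN(c4cccc(Cl)c4)CC3)cc2N1`, has not yet been measured in this assay. Its structural change from compound 1 is chloro in place of methyl on an aromatic carbon. Among the compounds with values here, no step between measured compounds shows how this assay responds to such a change, so the expectation rests on compound 1 alone, whose value of 490 nM in this assay gives the anchor. The step from compound 1 to compound 3 is expected to be a 1.2-fold lower number from compound 1 to compound 3 (0.07 log units; within the scatter), not beyond the scatter in either direction. Compound 3 is therefore estimated at 420 nM in this assay, with a range from 150 nM to 1200 nM.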

Compound 3, half-maximal inhibitory concentration: 190 nM
For compound 3 the middle estimate is 2.2-fold (0.34 log units) above the measured one; the range from low to high includes it.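

In this assay, going by these compounds alone, the change from 3-methylphenyl to 3-chlorophenyl gives the first step that can be read in this set: a 2.6-fold lower number from compound 1 to compound 3 (0.41 log units; beyond the scatter). This place on the aromatic ring, meta to a large group, therefore responds to the exchange of a single heavy atom, even though neither group brings a ring, a hydrogen-bond donor, a hydrogen-bond acceptor or a net charge, and the step lies beyond the usual scatter. Nothing measured here speaks to why the chloro compound gives the lower number, and no property of either group is available to account for it.

Compound 2 gives only a limit of the assay, > 9000 nM, and steps to it cannot be read. On these data alone, it remains open how the shared core would respond to a bromo, a methoxy or a nitrile at this place, and whether a single chloro elsewhere on the same ring would give a similar number.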